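This account rests on a few compounds, and the source may have more. Where it says the series, first, only, none or still open, it means among the compounds named here.

Compound 1 `CC(C)(C)c1ccc(C(=O)N2CCC3(CC2)C(=O)N(CC(=O)NCCC(=O)O)CN3c2ccccc2)cc1`: 11400 nM
Compound 2 `CC(C)(C)c1ccc(C(=O)N2CCC3(CC2)C(=O)N(CC(=O)N2CCCCC2CO)CN3c2ccccc2)cc1`: 11800 nM

Of the compounds shown here, two have so far been measured in an assay on HEK293 cells for displacement of a labelled ligand from NPC1-like intracellular cholesterol transporter 1 (Homo sapiens); a lower number here means a stronger inhibitor, a higher number a weaker inhibitor. Compound 1 gives 11400 nM in this assay, and compound 2 gives 11800 nM. Among the compounds with values here, compound 2 holds the higher of the two numbers, but its only neighbour, compound 1, sits within the scatter of it, so the two cannot be told apart. Within the data shown here, the single measured step, a 1.0-fold higher number from compound 1 to compound 2 (0.01 log units; within the scatter), exchanged one amide substituent for another on the carbonyl carbon and left the number essentially unchanged.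

Compound 3 `CC(C)(C)c1ccc(C(=O)N2CCC3(CC2)C(=O)N(CC(=O)NCCCCCO)CN3c2ccccc2)cc1` has not yet been measured in this assay. It differs from compound 2 by (5-hydroxypentyl)amino in place of 2-(hydroxymethyl)piperidin-1-yl on a carbonyl carbon. Among the measured compounds shown here, the only step that bears on this change is a 1.0-fold higher number from compound 1 to compound 2 (0.01 log units; within the scatter), in which the group on the same carbonyl carbon was replaced without any shift beyond the scatter. On that basis the expected step is a 1.1-fold lower number from compound 2 to compound 3 (0.03 log units; within the scatter), nothing beyond the scatter in either direction. Compound 3 is therefore estimated at 11000 nM in this assay, within a range from 5000 nM to 25000 nM.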

Compound 3, half-maximal inhibitory concentration: 9400 nM
For compound 3 the middle estimate is 1.2-fold (0.07 log units) above the measured one, and the stated range covers the measured number.
By their numbers in this assay, from the lowest: compounds 3, 1 and 2 (each within the scatter of the next).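

In this assay, (5-hydroxypentyl)amino in place of 2-(hydroxymethyl)piperidin-1-yl on the carbonyl carbon gives a 1.3-fold lower number from compound 2 to compound 3 (0.10 log units; within the scatter), so at this position a group with no ring reads the same as one carrying a six-membered non-aromatic ring, and the added hydrogen-bond donor leaves no mark that can be read. The second new comparison, 3-hydroxypropyl in place of carboxy on a saturated chain carbon, two bonds along the chain from an amide-type nitrogen, gives a 1.2-fold lower number from compound 1 to compound 3 (0.08 log units; within the scatter), so a chain ending in a hydroxyl group cannot be told apart from one ending in a carboxylic acid, and none of the three groups seen at this place separates from the others. No measurement offered here accounts for this flat reading.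

Going by these compounds, it remains open whether a primary amine at the end of the chain, a much longer alkyl chain or an aromatic ring such as phenyl at this place would move the number beyond the scatter. The compounds also leave open whether this insensitivity would hold on any core other than the shared one.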